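The compounds below may be only part of what the source reports. "The series", "measured", "known", "first", "only" and "open" are said of these compounds alone.

Measured so far:
Compound 1 `O=c1nc2ccc(Br)cn2cc1Cc1ccccc1` gives 137000 nM in a functional assay on SK-N-SH cells (Homo sapiens) for cytotoxicity, read by MTT assay, with a stated time of 24 h; on this read-out higher numbers stand for weaker inhibition and lower numbers for stronger inhibition.
Compound 2 `O=c1nc2ccccn2cc1Cc1ccc(Br)cc1` gives 163000 nM.
Compound 3 `O=c1nc2ccc(Br)cn2cc1Cc1ccc(Cl)cc1` gives 940 nM.

Compound 3 has the lowest number of the three, so it is the strongest inhibitor here; both other compounds sit well beyond the scatter above it. Compound 4 `O=c1nc2ccc(Br)cn2cc1Cc1ccc(Br)cc1` differs from compound 3 by bromo in place of chloro on an aromatic carbon. Among the compounds with values here, the one step measured at this place, a 150-fold lower number from compound 1 to compound 3 (2.16 log units; beyond the scatter), shows how much adding a chloro there changed the number. Within the data shown here, a swap of one halogen for another at the same spot has no measured counterpart, and compound 2, with a bromo at that spot but no bromo on the core, offers no direct comparison. The step to compound 4 is therefore expected to be small, a 1.2-fold lower number from compound 3 to compound 4 (0.07 log units; within the scatter), within the scatter. Compound 4 is estimated at 800 nM, between 300 nM and 2500 nM.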

Compound 4, half-maximal inhibitory concentration: 870 nM
Beside the measured number, compound 4's estimate is 1.1-fold (0.04 log units) below it; measured number inside the range.
By their numbers in this assay, from the lowest: compounds 4 and 3 (each within the scatter of the next); then compounds 1 and 2 (each within the scatter of the next).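

In this assay, this position takes either halogen: bromo in place of chloro gives a 1.1-fold lower number from compound 3 to compound 4 (0.03 log units; within the scatter). Bromo in place of hydrogen at this position gives a 160-fold lower number from compound 1 to compound 4 (2.20 log units; beyond the scatter), a large step like the one seen with chloro. The bromo on the core matters as well, since adding it gives a 190-fold lower number from compound 2 to compound 4 (2.27 log units; beyond the scatter), so neither bromo alone reaches the low numbers here.

As far as these compounds go, whether a non-halogen group at this position, such as an amine or a methoxy group, would also fit remains open. No measurement here explains why these halogens matter so much.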